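A few compounds are considered here, and "the series" means these few. Any claim that something is new, unique, unknown or untested is made for them only; others in the source may bear on it.

Series notes. Going by the values given here, compound 1 `CCCCCCCCc1ccc(OCC(=O)Cn2nnc(-c3ccccc3Cl)n2)cc1` is measured in an assay on microsomes from brain for inhibition of Fatty-acid amide hydrolase 1 (Rattus norvegicus), read by fluorescence and HPLC, with a stated time of 60 min (on this read-out higher numbers stand for weaker inhibition and lower numbers for stronger inhibition), at 32 nM, the lowest of the two numbers so far. Compound 2 `CCCCCCCCc1ccc(OCC(=O)Cn2nnc(-c3cccc(C(=O)OC)c3)n2)cc1` gives 34 nM in this assay; the step of a 1.1-fold higher number from compound 1 to compound 2 (0.03 log units; within the scatter) is within the scatter, so the two are not ordered against each other. Compound 3 `CCCCCCCCc1ccc(OCC(=O)Cn2nnc(Cc3ccccc3)n2)cc1` has not yet been measured in this assay. Against compound 1 it differs by benzyl in place of 2-chlorophenyl on an aromatic carbon. Among the compounds with values here, no measured step bears directly on this change: the one step available exchanges one aryl group for another on the same aromatic carbon and comes out flat, but compound 3 introduces a benzyl group instead, for which no comparison exists. The expectation is therefore a step of a 1.3-fold higher number from compound 1 to compound 3 (0.10 log units; within the scatter), with a range wide enough to cover movement either way. Compound 3 is estimated at 40 nM in this assay, with the range 10 nM to 160 nM.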

Compound 3, half-maximal inhibitory concentration: 66 nM
Compound 3: the middle estimate sits 1.7-fold (0.22 log units) below what was measured; low and high end bracket the measured number.
By their numbers in this assay, from the lowest: compounds 1, 2 and 3 (each within the scatter of the next, the first and the last beyond it).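

In this assay, benzyl in place of 2-chlorophenyl on this aromatic carbon of the five-membered aromatic ring gives a 2.1-fold higher number from compound 1 to compound 3 (0.31 log units; beyond the scatter), so this position is not wholly flat, as the exchange of one aryl group for another had suggested. The step is modest, however, and against the other aryl group it is not resolved: benzyl in place of 3-(methoxycarbonyl)phenyl gives a 1.9-fold higher number from compound 2 to compound 3 (0.29 log units; within the scatter). No measurement on hand bears on the origin of the step from compound 1 to compound 3.

Still open, as far as these compounds go, is whether the trend continues with phenethyl, a longer chain carrying the same six-membered aromatic ring, in place of benzyl. Also open, from the compounds shown here alone, is how this position responds to groups without an aromatic ring, such as an amine or a carboxylic acid.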